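Nitro-to-Bromo Exchange on Two Related Carbamate Cores

The compounds below may be only part of what the source reports. "The series", "measured", "known", "first", "only" and "open" are said of these compounds alone.

Measured compounds:
compound 1, `O=C(NCCCCc1ccccc1)n1c(=O)oc2cc([N+](=O)[O-])ccc21`, 3 nM
compound 2, `O=C(NCCCCc1ccccc1)n1c(=O)oc2cc(Br)ccc21`, 31 nM
compound 3, `O=C(NCCCCc1ccccc1)n1c(=O)oc2ccc([N+](=O)[O-])cc21`, 3 nM

In an assay on HEK293 cells for inhibition of acid ceramidase (Homo sapiens), with a stated time of 10 min (on this read-out lower numbers stand for stronger inhibition and higher numbers for weaker inhibition), compound 1 gives 3 nM, and compound 3 gives 3 nM, a value that agrees with that of compound 1 within the usual scatter. How the core of compound 3 differs from the core of compound 1 is not broken down here. Compound 2 gives 31 nM in this assay, so the step of a 10-fold higher number from compound 1 to compound 2 (1.01 log units; beyond the scatter) is large; it came with the change (bromo in place of nitro on an aromatic carbon).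

Compound 4, `O=C(NCCCCc1ccccc1)n1c(=O)oc2ccc(Br)cc21`, has not yet been measured. It differs from compound 3 by bromo in place of nitro on an aromatic carbon, which is the same change at the same kind of place as that between compound 1 and compound 2. The step from compound 3 to compound 4 in this assay is therefore expected to be a 10-fold higher number from compound 3 to compound 4 (1.00 log units; beyond the scatter), resting on the measured step of a 10-fold higher number from compound 1 to compound 2 (1.01 log units; beyond the scatter) and on compound 3 giving 3 nM, a value that agrees with that of compound 1. On that basis compound 4 is estimated at 30 nM, expected to fall between 10 nM and 90 nM.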

Compound 4, half-maximal inhibitory concentration: 22 nM
For compound 4 the middle estimate is 1.4-fold (0.13 log units) above the measured one; the range from low to high includes it.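

In this assay, bromo in place of nitro on an aromatic carbon again goes with weaker inhibition, with a 7.3-fold higher number from compound 3 to compound 4 (0.87 log units; beyond the scatter). Set beside the earlier step, this shows that the change carries over from the core of compound 1 to the core of compound 3 at a size that cannot be told apart from the first: the same change on two cores in this assay, a 10-fold higher number (1.01 log units; beyond the scatter) from compound 1 to compound 2 and a 7.3-fold higher number (0.87 log units; beyond the scatter) from compound 3 to compound 4, 1.4-fold (0.15 log units) apart, within the scatter of two such steps. This agreement rests on one change, two cores and one assay, so it does not show that the step would keep its size on any further core, and it says nothing about why the two groups differ.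

The compounds shown leave open how other groups in the same place, such as chloro, a nitrile or an amine, would compare with nitro and bromo. They also leave open whether the step would keep its size with a shorter or longer chain in place of the one that carries the phenyl ring.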